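Amide to Urea on a Pyrazole Scaffold: Expected Cytotoxicity

The source may report more compounds than this note shows. Statements on the series, on what has been measured and on what is new or still open speak of the compounds shown alone.

Measured so far:
compound 1 `COc1cc(-c2nn(-c3cccc(NC(=O)c4ccc(Cl)c(C(F)(F)F)c4)c3)cc2-c2ccncc2)ccc1Cl`, > 32500 nM
compound 2 `O=C(Nc1cccc(-n2cc(-c3ccncc3)c(-c3ccc(Cl)c(O)c3)n2)c1)Nc1cc(C(F)(F)F)cc(C(F)(F)F)c1`, > 50000 nM

Both compounds were tested in a functional assay on SK-OV-3 cells (Homo sapiens) for inhibition, read by sulforhodamine B assay, with a stated time of 48 h; on this read-out lower numbers stand for higher toxicity in this test and higher numbers for lower toxicity in this test. For compound 1 the result is only a limit of the test, > 32500 nM, and not a number. For compound 2 the result is likewise only a limit, > 50000 nM. Compound 1 therefore stands at a limit, and the other value shown is a limit as well the limit of > 32500 nM in this assay, at which 1 of the 2 values shown sits (the limit of > 50000 nM in this assay, at which 1 of the 2 values shown sits), so no numerical order between the two can be drawn.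

Compound 3 `COc1cc(-c2nn(-c3cccc(NC(=O)Nc4ccc(Cl)c(C(F)(F)F)c4)c3)cc2-c2ccncc2)ccc1Cl` has not yet been measured in this assay. It differs from compound 1 in one place: (4-chloro-3-(trifluoromethyl)phenyl)amino in place of 4-chloro-3-(trifluoromethyl)phenyl on a carbonyl carbon. Compound 2 already carries a urea of this kind and sits at a limit, which gives no sign that the change brings toxicity into the measurable range.

For the measured compounds named here, no measured step between compounds is available here, so the expectation rests on the two limits alone. The step that the limit leaves unreadable from compound 1 to compound 3 is expected to be none beyond the scatter. Compound 3 is estimated to give 40000 nM, within a range from 15000 nM to 100000 nM, most likely again reported only as a limit.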

Compound 3, concentration lethal to 50% of the cells: > 32500 nM
Compound 3: no number, only a limit; the forecaster's own chance of this, stated with the estimate: 80%; the middle value does not contradict the limit.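

For the compounds shown here, compound 1 and compound 3 both end at a limit of the test rather than a number, so no step between them can be read in this assay: the limit of > 32500 nM in this assay, at which 2 of the 3 values shown sit. The compounds shown leave open how toxic either compound is, and whether the change from the amide of compound 1 to the urea of compound 3 alters that toxicity at all.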